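A Ketone Becomes an Amide: Solubility in Question

The source may hold more compounds than are shown below. What is called first, only, known or untested is meant among the compounds shown, and "the series" means these compounds.

Of the compounds shown here, three sharing one core have been measured in a physicochemical assay for solubility, read by HPLC, in phosphate buffer, measured as kinetic solubility, at pH 7.4; on this read-out lower numbers stand for lower solubility and higher numbers for higher solubility. Compound 1 `CCC(=O)c1cc(-c2ccc(S(N)(=O)=O)cc2)n(-c2ccc(Cl)cc2)n1` gives 41900 nM. Compound 2 `CCC(=O)c1cc(-c2ccc(S(N)(=O)=O)cc2)n(-c2ccc(C(F)(F)F)cc2)n1`, which carries trifluoromethyl in place of chloro on an aromatic carbon, gives 7500 nM, and compound 3 `CCC(=O)c1cc(-c2ccc(S(N)(=O)=O)cc2)n(-c2ccc(OC)cc2)n1`, with methoxy in place of chloro on an aromatic carbon, gives 64300 nM. The two changes behave differently: a 5.6-fold lower number from compound 1 to compound 2 (0.75 log units; beyond the scatter), whereas a 1.5-fold higher number from compound 1 to compound 3 (0.19 log units; within the scatter). Compound 1 therefore sits well above compound 2, and within the scatter of compound 3.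

Compound 4 `CN(C(=O)c1cc(-c2ccc(S(N)(=O)=O)cc2)n(-c2ccc(Cl)cc2)n1)C1CC(F)(F)C1` is not yet measured. It differs from compound 1 at the carbonyl carbon: (3,3-difluorocyclobutyl)(methyl)amino in place of ethyl on a carbonyl carbon. The ketone of compound 1 thus becomes an amide bearing a four-membered carbon ring with two fluorines.

Going by the values given here, none of the measured steps touches this position; all three swap a group on the aromatic ring that sits on the nitrogen of the core, so no step here indicates how the carbonyl side governs this assay. With only the value of compound 1 as an anchor, a change in either direction is possible. The expected step is a 1.4-fold lower number from compound 1 to compound 4 (0.15 log units; within the scatter), a modest move that may stay within the scatter. Compound 4 is therefore expected to give 30000 nM, between 8000 nM and 100000 nM.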

Compound 4, solubility: 30900 nM
The estimate for compound 4 lay 1.0-fold (0.01 log units) below the measured number; measured number inside the range.
By their numbers in this assay, from the lowest: compound 2; then compounds 4, 1 and 3 (each within the scatter of the next, the first and the last beyond it).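

In this assay, the step from ethyl to (3,3-difluorocyclobutyl)(methyl)amino on the carbonyl carbon is a 1.4-fold lower number from compound 1 to compound 4 (0.13 log units; within the scatter), so by this read-out compound 4 and compound 1 cannot be told apart. Going by these compounds alone, this is the first view of the carbonyl side: turning the ketone into an amide and adding a four-membered ring with two fluorines is a large change in structure, yet in this one pair it leaves the number within the scatter, whereas a single swap elsewhere on the molecule gave a 5.6-fold lower number from compound 1 to compound 2 (0.75 log units; beyond the scatter). No measurement shown here accounts for this result.

Because the amide nitrogen, the ring and the fluorines all enter together, this single pair cannot separate their contributions, and a plain dimethylamino group, an unfluorinated cyclobutyl(methyl)amino group or a morpholine ring on the same carbonyl carbon would help to pull them apart. Going by these compounds, it also remains open whether the same (3,3-difluorocyclobutyl)(methyl)amino group would behave alike with trifluoromethyl or methoxy in place of chloro, or whether a group carrying an amine or a carboxylic acid at the carbonyl carbon would move the number beyond the scatter.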